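The compounds below may be only part of what the source reports. "The series", "measured", "known", "first", "only" and "open" are said of these compounds alone.

Working notes on the series. In a functional assay on HeLa cells (Homo sapiens) for cytotoxicity, read by WST assay, with a stated time of 48 h (a higher number here means that more compound is needed for the effect, a lower number that less compound is needed), compound 1 `O=C1OC[C@H](Cc2ccccc2)[C@H]1Cc1ccc(Cl)c(Cl)c1` gives 26000 nM and compound 2 `COc1ccccc1C[C@H]1COC(=O)[C@@H]1Cc1ccc(Cl)c(Cl)c1` gives 24000 nM. These two values lie within the scatter of each other, so compound 1 cannot be separated from compound 2 on the numbers available. For compound 3 `O=C1OC[C@H](Cc2ccccc2F)[C@H]1Cc1ccc(Cl)c(Cl)c1` the entry reads "not determined" (no result reported), so it adds no number to the comparison.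

The next compound to be tested is compound 4 `CCCCc1ccc(C[C@H]2COC(=O)[C@@H]2Cc2ccc(Cl)c(Cl)c2)cc1`. It carries butyl in place of hydrogen on an aromatic carbon, para to a large group, and keeps the rest of compound 1: butyl in place of hydrogen on an aromatic carbon.

For the measured compounds named here, only one measured step bears on this change. Methoxy in place of hydrogen on an aromatic carbon gives a 1.1-fold lower number from compound 1 to compound 2 (0.03 log units; within the scatter). That step shows a substitution on an aromatic carbon with no change beyond the scatter in this assay. However, it involves a different group, and the series holds no measured butyl example, so it is weak guidance. No clear direction can be drawn from it, and the range has to stay wide.

The expected step is a 1.4-fold lower number from compound 1 to compound 4 (0.16 log units; within the scatter), which means no firm shift is anticipated. For compound 4 the estimated value is 18000 nM, with an expected range of 6000 nM to 42000 nM.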

Compound 4, half-maximal effective concentration: 27000 nM
Compound 4: middle estimate off by 1.5-fold (0.18 log units), on the low side; low and high end bracket the measured number.
By their numbers in this assay, from the lowest: compounds 2, 1 and 4 (each within the scatter of the next).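

In this assay, butyl in place of hydrogen on an aromatic carbon, para to a large group, gives a 1.0-fold higher number from compound 1 to compound 4 (0.02 log units; within the scatter). Compound 4 is the only compound with a measured value that carries a substituent para to a large group, and its butyl group, with 4 heavy atoms and no ring, is the only alkyl chain among the aromatic substituents shown. At this place on the ring, the shared core therefore accepts a chain of this size with no change beyond the scatter, which extends the result for the methoxy group in compound 2 to a different group and a different position. Nothing available on these compounds accounts for the lack of a shift.

It remains open whether any group at this place can move the number beyond the scatter, since the compounds shown include no amine, carboxylic acid or longer chain there. The series also does not show whether butyl would behave the same way at other carbons of this ring, or on the dichlorinated ring.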